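The source may hold more compounds than are shown below. What is called first, only, known or untested is meant among the compounds shown, and "the series" means these compounds.

Measured compounds:
compound 1 `O=C(Nc1ccc(C(=O)N2CCCN(CCN3CCCC3)c3sccc32)cc1)c1ccccc1-c1ccccc1` gives 10 nM in an assay on adrenal medulla for inhibition of Vasopressin V2 receptor (Rattus norvegicus), read by radioligand binding; a lower number here means a stronger inhibitor, a higher number a weaker inhibitor
compound 2 `CN1CCN(CCCCOc2cc(C(=O)N3CCCCc4sccc43)ccc2NC(=O)c2ccccc2-c2ccccc2)CC1` gives 7 nM in this assay
compound 3 `CN(C)CCN1CCCN(C(=O)c2ccc(NC(=O)c3ccccc3-c3ccccc3)cc2)c2ccsc21` gives 20 nM in this assay

Compound 2 carries the lowest number of the three; compound 1 lies within the scatter of it, and only compound 3 sits beyond the scatter above it. Compound 2 and compound 1 differ in several places at once, so their gap is not read as a single step.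

Compound 4 `CN1CCCN(CCCOc2cc(C(=O)N3CCCCc4sccc43)ccc2NC(=O)c2ccccc2-c2ccccc2)CC1` is the next member. It differs from compound 2 in this way: 4-methyl-1,4-diazepan-1-yl in place of (4-methylpiperazin-1-yl)methyl on a saturated chain carbon, three bonds along the chain from an oxygen on an aromatic ring. The basic end of the side chain is thus rebuilt from the same atoms, with one ring carbon moved out of the chain and into the ring.

Among the compounds with values here, the one measured single-point step concerns the same region, the amine at the end of the chain: a 2.0-fold higher number from compound 1 to compound 3 (0.30 log units; within the scatter). That step, which swaps one amine for another, stays within the scatter. Nothing measured here separates a six-membered from a seven-membered amine ring, so the expectation rests on that step alone: a change in this assay of no more than the scatter, in either direction, is expected for compound 4, that is a 1.3-fold higher number from compound 2 to compound 4 (0.11 log units; within the scatter). Compound 4 is therefore estimated at 9 nM, within 4 nM to 22 nM.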

Compound 4, half-maximal inhibitory concentration: < 1 nM
Compound 4: no number, only a limit; the forecaster's own chance of this, stated with the estimate: 0%; at least 9.0-fold (0.95 log units) between middle value and limit.
By their numbers in this assay, from the lowest: compounds 2, 1 and 3 (each within the scatter of the next, the first and the last beyond it). At a limit, below all of these: compound 4.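

Replacing the (4-methylpiperazin-1-yl)methyl end with 4-methyl-1,4-diazepan-1-yl, on a saturated chain carbon three bonds along the chain from an oxygen on an aromatic ring, gives an at least 7.0-fold lower number from compound 2 to compound 4 (0.84 log units; beyond the scatter) in this assay, although the two side chains have the same atoms, joined differently. Within the data shown here, the only earlier step at an amine end, a 2.0-fold higher number from compound 1 to compound 3 (0.30 log units; within the scatter), stayed within the scatter and sits on a different chain, so this is the first sign that the arrangement of the amine end can move the reading beyond the scatter. The reading for compound 4 is a limit of the assay and not a number: the limit of < 1 nM in this assay, at which 1 of the 4 values shown sits.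

As far as these compounds go, the full size of the step stays open, and so does its source, since the same difference also reads as 4-(4-methylpiperazin-1-yl)butyl to 3-(4-methyl-1,4-diazepan-1-yl)propyl, with ring size and chain length changing together. A 3-(4-methylpiperazin-1-yl)propyl chain on the same oxygen would separate the two, and a morpholine ring at the chain end would test whether the second ring nitrogen matters.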